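This account rests on a few compounds, and the source may have more. Where it says the series, first, only, none or still open, it means among the compounds named here.

Compound 3 `Cn1cc2nc(Cc3ccccc3)nc(N)c2n1` gives 9% in an assay on CHO cells for displacement of a labelled ligand from adenosine receptor A1 (Homo sapiens), read by scintillation counting, with a stated time of 120 min, tested at 1 uM; a higher number here means more inhibition at the concentration tested (going by the name of the read-out), a lower number less inhibition. Among the three compounds measured, it sits nearest compound 1 `COc1ccccc1-n1cc2nc(-c3ccc(C)o3)nc(N)c2n1`, which gives 1%, a gap within the usual scatter, and furthest from compound 2 `COc1ccccc1-n1cc2nc(-c3ccco3)nc(N)c2n1`, which gives 31%, a gap beyond it. Among the compounds with values here, the one step between measured compounds that differ in a single place is a number 30 percentage points higher from compound 1 to compound 2 (beyond the scatter); it concerns a different group at a different place and so says little about the change at hand, (phenyl in place of hydrogen on a saturated chain carbon bound to an aromatic nitrogen), which leads to compound 4 `Nc1nc(Cc2ccccc2)nc2cn(Cc3ccccc3)nc12`. Within the data shown here, with no directly comparable step, only a small change, not beyond the scatter, is expected: a number 3 percentage points higher from compound 3 to compound 4 (within the scatter). Compound 4 is therefore estimated at 12%, between 0% and 40%.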

Compound 4, a percentage reported as inhibition, at one concentration (the size of the read-out at that concentration, not a potency): 1%
Compound 4: the middle estimate sits 11 percentage points above what was measured, within the range that was stated.
By their numbers in this assay, from the lowest: compounds 1, 4 and 3 (each within the scatter of the next); then compound 2.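

In this assay, going from methyl to benzyl gives a number 8 percentage points lower from compound 3 to compound 4 (within the scatter), so adding phenyl on a saturated chain carbon bound to an aromatic nitrogen produces no change that can be told from the scatter. At this single concentration, the inhibition in this assay is therefore level for compound 3 and compound 4. Nothing available bears on why this is so. The compounds shown leave open whether an amine, a carboxylic acid or a longer alkyl chain at this position would give a different reading. They also leave open whether phenyl would behave the same way on a core carrying furan.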